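Swapping hydroxy for ethyl in compound 2

The source may hold more compounds than are shown below. What is called first, only, known or untested is meant among the compounds shown, and "the series" means these compounds.

In an ADME assay on HEK293 cells (Homo sapiens) for cytotoxicity, read by resazurin assay, with a stated time of 48 h (a lower number here means that less compound is tolerated, a higher number that more compound is tolerated), compound 1 (`O=S(=O)(Nc1ccc2oc(-c3ccccc3)nc2c1)c1cccs1`) gives 97000 nM. Compound 2 (`O=S(=O)(Nc1ccc2oc(-c3ccccc3)nc2c1)c1ccc(O)cc1`) stands at > 100000 nM, which is a limit of the assay and not a number. Compound 3 (`CCc1ccc(S(=O)(=O)Nc2ccc3oc(-c4ccccc4)nc3c2)cc1`) has ethyl in place of hydroxy on an aromatic carbon, para to a large group: ethyl in place of hydroxy on an aromatic carbon. For the measured compounds named here, the only measured step, an at least 1.0-fold higher number from compound 1 to compound 2 (0.01 log units; that floor lies within the scatter), involves a different change at the same end of the molecule, and its full size is left open by the limit of > 100000 nM in this assay, at which 1 of the 2 values shown sits. In this assay, no step beyond the scatter is therefore expected, and the estimated change is an at least 1.2-fold lower number from compound 2 to compound 3 (0.09 log units; that floor lies within the scatter). For compound 3 the expected value is 80000 nM, with an estimated range of 30000 nM to 150000 nM.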

Compound 3, half-maximal cytotoxic concentration: 81000 nM
Compound 3: middle estimate off by 1.0-fold (0.01 log units), on the low side; low and high end bracket the measured number.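

In this assay, ethyl in place of hydroxy on the aromatic carbon gives an at least 1.2-fold lower number from compound 2 to compound 3 (0.09 log units; that floor lies within the scatter). As far as these compounds go, the full size of this step stays open because compound 2 carries a limit of the assay and not a number: the limit of > 100000 nM in this assay, at which 1 of the 3 values shown sits. On the sulfonyl sulfur, 4-ethylphenyl in place of thiophen-2-yl gives a 1.2-fold lower number from compound 1 to compound 3 (0.08 log units; within the scatter), so these two groups cannot be told apart here.

The compounds shown leave open whether an amine, a carboxylic acid or a longer chain at this same aromatic carbon would move the number beyond the scatter.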